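Ester to Amide: What to Expect for Compound 4

The source may report more compounds than this note shows. Statements on the series, on what has been measured and on what is new or still open speak of the compounds shown alone.

Compound 1 `CCOC(=O)c1cscc1-c1ccc(OC)c(OC)c1`: 3%
Compound 2 `CCOC(=O)c1c(-c2ccc(OC)c(OC)c2)csc1NC(N)=O`: 14%
Compound 3 `COc1ccc(-c2csc(N)c2C(=O)OCc2ccccc2)cc1OC`: 100%

In an assay on isolated protein for inhibition of protein kinase C zeta type (Homo sapiens), with stated times of 1 h and 2.5 min, tested at 30 uM (on this read-out higher numbers stand for more inhibition at the one concentration tested (going by the name of the read-out) and lower numbers for less inhibition), compound 1 gives 3% and compound 2 gives 14%. Among the compounds with values here, the only measured step, a number 11 percentage points higher from compound 1 to compound 2 (beyond the scatter), changes an aromatic carbon, not the carbonyl. Compound 3 stands highest of the three with 100%, clearly beyond the scatter above both others. Compound 4 `COCCNC(=O)c1c(-c2ccc(OC)c(OC)c2)csc1N` is not yet measured. It differs from compound 3 by (2-methoxyethyl)amino in place of benzyloxy on a carbonyl carbon. Within the data shown here, no measured step touches the carbonyl carbon, so nothing here tells how this change will act, and the expectation is wide. For compound 4 the estimate in this assay is 60%, from 15% to 100%. That estimate corresponds to an expected step of a number 40 percentage points lower from compound 3 to compound 4 (beyond the scatter).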

Compound 4, a percentage reported as inhibition, at one concentration (the size of the read-out at that concentration, not a potency): 55%
Beside the measured number, compound 4's estimate is 5 percentage points above it; the measured number falls inside the stated range.
By their numbers in this assay, from the lowest: compound 1; then compound 2; then compound 4; then compound 3.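

In this assay, within the data shown here, the carbonyl carbon proves to be a place where the group matters: (2-methoxyethyl)amino in place of benzyloxy gives a number 45 percentage points lower from compound 3 to compound 4 (beyond the scatter), the first measured change at this position. Even so, compound 4 gives 55% without the six-membered aromatic ring of benzyloxy, so that ring is not needed for all of the inhibition. Nothing measured here explains the drop.

Still open, from the compounds shown here alone, is whether the ring or the switch from ester to amide carries the step. Benzylamino on this carbonyl carbon, which pairs the ring with an amide hydrogen, would separate the two.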